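A few compounds are considered here, and "the series" means these few. Any claim that something is new, unique, unknown or untested is made for them only; others in the source may bear on it.

The series shares one core, seen in compound 1 `N#CC1=C(N)OC(c2c[nH]c3ccccc23)=C(C#N)C1c1ccccc1F`, compound 2 `COc1ccc(C2C(C#N)=C(N)OC(c3c[nH]c4ccccc34)=C2C#N)cc1OC`, compound 3 `Cc1ccc(C2C(C#N)=C(N)OC(c3c[nH]c4ccccc34)=C2C#N)cc1` and the still unmeasured compound 4 `N#CC1=C(N)OC(c2c[nH]c3ccccc23)=C(C#N)C1c1cccc2ccccc12`; the compounds differ only in the aryl group on a saturated ring carbon. In a functional assay, tested at 50 ug/mL (on this read-out higher numbers stand for a stronger effect at the one concentration tested and lower numbers for a weaker effect), compound 1 is reported as "not active" (no number reported), with no number given. In this assay compound 2 gives 14.5%, and compound 3 gives 5.2%. Of the two numbers in this assay that of compound 3 is the smaller, yet the step of a number 9.3 percentage points lower from compound 2 to compound 3 (within the scatter) lies within the scatter, so the two cannot be told apart on this read-out.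

The change to compound 4 is naphthalen-1-yl in place of 4-methylphenyl on a saturated ring carbon. Among the measured compounds shown here, the only measured step that bears on it is the one exchanging the aryl group on that carbon, a number 9.3 percentage points lower from compound 2 to compound 3 (within the scatter), and it stayed within the scatter. For the measured compounds named here, a larger aryl group has no precedent in the set, so nothing points to a step beyond the scatter in either direction. Compound 4 is therefore expected to remain near compound 3, with an estimated step of a number 2.8 percentage points higher from compound 3 to compound 4 (within the scatter). Compound 4 is estimated at 8%, within a range of 0% to 25%.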

Compound 4, a percentage reported as activity, at one concentration (the size of the read-out at that concentration, not a potency): 4.7%
Beside the measured number, compound 4's estimate is 3.3 percentage points above it; the measured number falls inside the stated range.
By their numbers in this assay, from the lowest: compounds 4, 3 and 2 (each within the scatter of the next).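

In this assay, putting two six-membered aromatic rings of carbon only in place of one on the saturated ring carbon gives a number 0.5 percentage points lower from compound 3 to compound 4 (within the scatter), so the exchange of 4-methylphenyl for naphthalen-1-yl leaves no readable mark on this read-out. The comparison with the 3,4-dimethoxyphenyl compound gives a number 9.8 percentage points lower from compound 2 to compound 4 (within the scatter), which means that 3,4-dimethoxyphenyl, 4-methylphenyl and naphthalen-1-yl all stand within the scatter of one another at this position, and the added ring does not separate compound 4 from either of the other two. No measurement in hand offers an explanation for this result.

Steps to compound 1 cannot be read, as it carries no number, and a read-out at one concentration says nothing of potency for any of these compounds. Going by these compounds, it remains open whether an aryl group bearing a carboxylic acid or an amine, or a cyclohexyl group in place of the aryl group, would give a step beyond the scatter at this saturated ring carbon.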